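A few compounds are considered here, and "the series" means these few. Any claim that something is new, unique, unknown or untested is made for them only; others in the source may bear on it.

Measured so far in an ADME assay on Vero cells (Chlorocebus sabaeus) for cytotoxicity, read by resazurin assay, with a stated time of 2 days; on this read-out lower numbers stand for higher toxicity in this test and higher numbers for lower toxicity in this test:
- compound 1 `COc1cc([N+](=O)[O-])ccc1NC(=S)Nc1cccc(/C=C/C(=O)C[C@@H]2O[C@H](CO)[C@@H](O)[C@H](O)[C@H]2O)c1`: compound 1 gives 203000 nM
- compound 2 `Cc1ccc(S(=O)(=O)Nc2cccc(/C=C/C(=O)C[C@@H]3O[C@H](CO)[C@@H](O)[C@H](O)[C@@H]3O)c2)cc1`: compound 2 gives 417000 nM
- compound 3 `O=C(/C=C/c1cccc(NC(=O)Nc2ccccc2)c1)C[C@@H]1OC[C@@H](O)[C@H](O)[C@H]1O`: compound 3 gives 309000 nM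

Compound 1 stands at the lowest of the three numbers in this assay. Its nearest neighbour is compound 3, whose number is higher by an amount within the scatter, so the two cannot be ordered. Compound 2 sits furthest away, with a number beyond the scatter above compound 1; on this read-out compound 2 is therefore the less toxic of that pair.

The next compound in the series is compound 4 `O=C(/C=C/c1cccc(NC(=S)Nc2ccccc2)c1)C[C@@H]1O[C@H](CO)[C@@H](O)[C@H](O)[C@H]1O`, which carries phenyl in place of 2-methoxy-4-nitrophenyl on an amide-type nitrogen. Among the measured compounds shown here, no pair of measured compounds that differ in only one place is available, so the size of this step cannot be read from existing numbers. All three measured values lie within a narrow band at the upper end of the concentration range, and compound 3, which also carries a plain phenyl on one nitrogen, gives a number within the scatter of compound 1. The step from compound 1 to compound 4 is therefore expected to be small, a 1.4-fold higher number from compound 1 to compound 4 (0.14 log units; within the scatter), not beyond the scatter in either direction. For compound 4 the estimate in this assay is 280000 nM, with a range from 140000 nM to 560000 nM.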

Compound 4, half-maximal cytotoxic concentration: 371000 nM
Estimate against measurement, compound 4: 1.3-fold (0.12 log units) below; measured number inside the range.
By their numbers in this assay, from the lowest: compounds 1, 3, 4 and 2 (each within the scatter of the next, the first and the last beyond it).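

In this assay the series now has its first pair that differs in one place: phenyl in place of 2-methoxy-4-nitrophenyl, on an amide-type nitrogen whose other neighbour is the thiocarbonyl carbon, gives a 1.8-fold higher number from compound 1 to compound 4 (0.26 log units; within the scatter) and so the two compounds cannot be ordered. This position therefore accepts the change from 11 heavy atoms to 6, with the loss of 3 hydrogen-bond acceptors, without a step beyond the scatter on this read-out. The methoxy and nitro groups leave together in this pair, and no supporting data bear on why the step is this small.

Compounds 2 and 3 each differ from compound 4 in more than one place, so no step can be read for the thiocarbonyl, the hydroxymethyl group or any other part of the shared core. Also open, going by these compounds, is whether a non-aromatic group at the same nitrogen, such as a cyclohexyl or a chain ending in a carboxylic acid, would stay within the scatter of compound 4 in this assay as phenyl does relative to 2-methoxy-4-nitrophenyl.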